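Branching the Imine Substituent in a Cyanobenzyl Series

A few compounds are considered here, and "the series" means these few. Any claim that something is new, unique, unknown or untested is made for them only; others in the source may bear on it.

Compound 1 `C/N=c1\c(O)c(O)\c1=N/Cc1ccc(C#N)cc1`: in a functional assay for inhibition, with Rattus norvegicus as the target (on this read-out higher numbers stand for weaker inhibition and lower numbers for stronger inhibition), compound 1 gives only a limit of the assay, > 30000 nM.
Compound 2 `CC[C@@H](C)/N=c1\c(O)c(O)\c1=N/Cc1ccc(C#N)cc1`: in this assay compound 2 gives 4000 nM.
Compound 3 `CC(C)(C)/N=c1\c(O)c(O)\c1=N/Cc1c(F)cccc1F`: in this assay compound 3 gives 7500 nM.

Compound 2 and compound 3 give numbers that lie within the scatter of each other, and the remaining value for compound 1 is a limit rather than a number. The single measured step, an at least 7.5-fold lower number from compound 1 to compound 2 (0.87 log units; beyond the scatter), starts from the limit of > 30000 nM in this assay, at which 1 of the 3 values shown sits, so its true size is at least what is shown. Compound 4 `CCC(C)(C)/N=c1\c(O)c(O)\c1=N/Cc1ccc(C#N)cc1` differs from compound 2 by 1,1-dimethylpropyl in place of sec-butyl on a double-bonded nitrogen. This step adds a carbon to an already branched group, whereas the measured step went from methyl to sec-butyl; compound 3 carries a different benzyl group and gives no direct comparison. A small change is therefore expected, toward a lower number if anything, as a 1.3-fold lower number from compound 2 to compound 4 (0.12 log units; within the scatter). For compound 4 the estimate in this assay is 3000 nM, expected to fall between 1000 nM and 10000 nM.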

Compound 4, half-maximal inhibitory concentration: 1100 nM
Compound 4: the middle estimate sits 2.7-fold (0.44 log units) above what was measured, within the range that was stated.
By their numbers in this assay, from the lowest: compound 4; then compounds 2 and 3 (each within the scatter of the next). At a limit, above all of these: compound 1.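

Compound 2 had shown only that sec-butyl gave a measurable number where methyl gave a limit. Compound 4 shows that this position still responds once the group is already branched: in this assay, 1,1-dimethylpropyl in place of sec-butyl gives a 3.6-fold lower number from compound 2 to compound 4 (0.56 log units; beyond the scatter), so the difference between two branched groups on the double-bonded nitrogen lies beyond the scatter. Taken from methyl, the whole change gives an at least 27-fold lower number from compound 1 to compound 4 (1.43 log units; beyond the scatter), and that size is only a lower bound, set by a limit: the limit of > 30000 nM in this assay, at which 1 of the 4 values shown sits.

From the compounds shown here alone, whether the number keeps falling with a larger group on this nitrogen, such as cyclohexyl or adamantyl, remains open. Also open, going by these compounds, is whether a chain ending in an amine or a hydroxyl would be tolerated there.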